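A few compounds are considered here, and "the series" means these few. Any claim that something is new, unique, unknown or untested is made for them only; others in the source may bear on it.

Of the compounds shown here, two have been measured in a functional assay on MCF7 cells (Homo sapiens) for inhibition, read by MTT assay, with a stated time of 72 h; on this read-out lower numbers stand for stronger inhibition and higher numbers for weaker inhibition. Among the compounds with values here, compound 1 (`Cc1cc(Nc2cc(-c3ccccc3)[nH]n2)n2nc(SCc3ccc(F)cc3)nc2n1`) gives 4020 nM, and compound 2 (`CCCCCc1c(C)nc2nc(SCc3ccc(Cl)cc3)nn2c1Nc1cc(-c2ccccc2)[nH]n1`) gives 6390 nM, which places compound 2 within the scatter of the only other number available. The unmeasured compound 3 (`Cc1nc2nc(SCc3ccc(Cl)cc3)nn2c(Nc2cc(-c3ccccc3)[nH]n2)c1C`) differs from compound 2 in one place: on a saturated chain carbon bound to an aromatic carbon, hydrogen stands in place of butyl, so that pentyl becomes methyl (hydrogen in place of butyl on a saturated chain carbon bound to an aromatic carbon). Within the data shown here, no measured pair differs in just one place, so the data hold no direct precedent for this change. The estimated step of a 1.3-fold lower number from compound 2 to compound 3 (0.11 log units; within the scatter) is expected to be small, toward a lower number and within the scatter. That expectation rests on compound 1 at 4020 nM, the only other measured reference. For compound 3 the expected value is 5000 nM, with an estimated range of 2000 nM to 12000 nM.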

Compound 3, half-maximal inhibitory concentration: 10600 nM
Beside the measured number, compound 3's estimate is 2.1-fold (0.33 log units) below it, within the range that was stated.
By their numbers in this assay, from the lowest: compounds 1, 2 and 3 (each within the scatter of the next, the first and the last beyond it).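

Within the data shown here, this is the first pair that differs in one place only, so the place on a saturated chain carbon bound to an aromatic carbon can now be read directly. In this assay, hydrogen in place of butyl, which turns pentyl into methyl, gives a step (a 1.7-fold higher number from compound 2 to compound 3 (0.22 log units; within the scatter)), so in this pair the two chain lengths are not told apart by the read-out. No measurement shown here bears on this result.

Going by these compounds, what an amine, a carboxylic acid or a chain longer than pentyl would give at this place stays open. On these data alone, it also stays open whether the same change would give a step of this size when the rest of the molecule is different.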